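From an anilino to a 4-methylphenyl group on the carbonyl

This account rests on a few compounds, and the source may have more. Where it says the series, first, only, none or still open, it means among the compounds named here.

Compound 1 `Cc1cc2c(C(C)C)ccc(C)c2cc1OC(=O)c1ccc([N+](=O)[O-])cc1`: 2280 nM
Compound 2 `CC1=CC[C@H](C(C)C)c2cc(C)c(OC(=O)Nc3ccccc3)cc21`: 300 nM

Both were tested in a functional assay on K562 cells (Homo sapiens) for antiproliferative activity, read by sulforhodamine B assay, with a stated time of 48 h; a lower number here means a stronger inhibitor, a higher number a weaker inhibitor. Compound 2 gives the lower of the two numbers, and compound 1 a higher one, by a margin beyond the scatter. The two differ in the core as well as in the group on the carbonyl carbon, so that gap cannot be tied to one change.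

Compound 3 `CC1=CC[C@H](C(C)C)c2cc(C)c(OC(=O)c3ccc(C)cc3)cc21` keeps the core of compound 2 and alters one place: 4-methylphenyl in place of anilino on a carbonyl carbon. Within the data shown here, no measured pair shows this change alone, so no step size is known for it, and compound 1, with a different core and a different group, offers no direct guide. A small loss is expected, possibly still within the scatter, with the step from compound 2 to compound 3 expected as a 2.0-fold higher number from compound 2 to compound 3 (0.30 log units; within the scatter). Compound 3 is estimated at 600 nM, within 150 nM to 2500 nM.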

Compound 3, half-maximal inhibitory concentration: 30900 nM
Estimate against measurement, compound 3: 52-fold (1.71 log units) below; the whole stated range lies below it.
By their numbers in this assay, from the lowest: compound 2; then compound 1; then compound 3.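

In this assay the change from anilino to 4-methylphenyl on a carbonyl carbon gives a 100-fold higher number from compound 2 to compound 3 (2.01 log units; beyond the scatter) on the shared core, so this place is far less tolerant of change than compounds 1 and 2 alone could show. The two groups match in heavy-atom count and each holds one six-membered aromatic ring of carbon only, yet they differ in two ways: anilino has a nitrogen with one hydrogen-bond donor, while 4-methylphenyl has neither but carries a methyl group. Nothing available here explains the size of this step.

Which of these differences matters remains open. A 4-methylanilino group on the same carbonyl carbon would keep the nitrogen and add the methyl, while an unsubstituted phenyl group would remove the nitrogen without adding the methyl, so each would separate the two differences.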